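A few compounds are considered here, and "the series" means these few. Any claim that something is new, unique, unknown or untested is made for them only; others in the source may bear on it.

In an in vitro ADME assay on microsomes (Mus musculus) for metabolic stability (on this read-out higher numbers stand for a longer-lived compound and lower numbers for a shorter-lived compound), compound 1 `CNC(=O)Nc1ccc(-c2nc(N3CC4CCC(C3)O4)c3cnn(CCN(C)C)c3n2)cc1` gives 0.0833 h and compound 2 `CNC(=O)Nc1ccc(-c2nc(N3CC4CCC(C3)O4)c3cnn([C@H]4CC[C@@H](OC)CC4)c3n2)cc1` gives 0.283 h. Compound 3 `O=C(Nc1ccccc1)Nc1ccc(-c2nc(N3CC4CCC(C3)O4)c3cnn(C4CCC5(CC4)OCCO5)c3n2)cc1` reaches only a limit of the assay, not a number, > 0.5 h (the limit of > 0.5 h in this assay, at which 1 of the 3 values shown sits). Among the two numbers compound 2 stands highest; its nearest neighbour is compound 1, and a 3.4-fold higher number from compound 1 to compound 2 (0.53 log units; beyond the scatter) is the only step measured so far. Compound 4 `CCn1ncc2c(N3CC4CCC(C3)O4)nc(-c3ccc(NC(=O)NC)cc3)nc21` differs from compound 2 by ethyl in place of 4-methoxycyclohexyl on an aromatic nitrogen. Within the data shown here, no measured step covers this exchange; the one step available concerns the same aromatic nitrogen but a different pair of groups, so it guides direction only loosely. A modest fall is expected, a 1.9-fold lower number from compound 2 to compound 4 (0.28 log units; within the scatter). Compound 4 is therefore estimated in this assay at 0.15 h, between 0.05 h and 0.45 h.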

Compound 4, half-life: > 0.5 h
Compound 4: no number, only a limit; the forecaster's own chance of this, stated with the estimate: 10%; middle value at least 3.3-fold (0.52 log units) away from the limit.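

In this assay compound 4 gives only a limit, > 0.5 h, so the 4-methoxycyclohexyl ring is not required on this aromatic nitrogen for a reading at the top of the range. Ethyl shows no loss against that ring, with an at least 1.7-fold higher number from compound 2 to compound 4 (0.24 log units; that floor lies within the scatter). The clearer change is hydrogen in place of dimethylamino on the chain, with an at least 6.0-fold higher number from compound 1 to compound 4 (0.77 log units; beyond the scatter).

On these data alone, how far compound 4 lies past the limit stays unknown: the limit of > 0.5 h in this assay, at which 2 of the 4 values shown sit. As far as these compounds go, whether a methyl, a propyl or a 2-hydroxyethyl group on this nitrogen gives the same reading remains open.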